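This account rests on a few compounds, and the source may have more. Where it says the series, first, only, none or still open, it means among the compounds named here.

Values measured in a functional assay on HeLa cells (Homo sapiens) for inhibition, read by MTT assay, with a stated time of 48 h; a lower number here means a stronger inhibitor, a higher number a weaker inhibitor:
- compound 1 `Oc1ccc(C(c2c[nH]c3ccc(Br)cc23)c2c[nH]c3ccc(Br)cc23)cc1`: 4000 nM
- compound 2 `Brc1ccc(C(c2c[nH]c3ccc(Br)cc23)c2c[nH]c3ccc(Br)cc23)cc1`: 1500 nM

Of these two, compound 2 has the lower number, at 1500 nM. Within the data shown here, the only measured step is a 2.7-fold lower number from compound 1 to compound 2 (0.43 log units; beyond the scatter), a modest change made on the aromatic ring while the ring itself stays in place.

The next compound is compound 3 `CCCCCCCC(c1c[nH]c2ccc(Br)cc12)c1c[nH]c2ccc(Br)cc12`, which replaces the ring-bearing group of compound 2: heptyl in place of 4-bromophenyl on a saturated chain carbon bound to two aromatic carbons. This is a different kind of change, as heptyl has no ring. Among the measured compounds shown here, no measured compound lacks the 4-bromophenyl or related aromatic ring, so the data give no direct guide to this replacement. The step of a 2.7-fold lower number from compound 1 to compound 2 (0.43 log units; beyond the scatter) serves only as a rough gauge of size, showing how far a single change has moved the number in this small series.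

In this assay, a modest move to a higher number is expected, though with low confidence. The expected change is a 2.3-fold higher number from compound 2 to compound 3 (0.37 log units; beyond the scatter). Compound 3 is estimated at 3500 nM, with an expected range from 1000 nM to 12000 nM.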

Compound 3, half-maximal inhibitory concentration: 1300 nM
The estimate for compound 3 lay 2.7-fold (0.43 log units) above the measured number; low and high end bracket the measured number.
By their numbers in this assay, from the lowest: compounds 3 and 2 (each within the scatter of the next); then compound 1.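

Read in this assay the aromatic ring on the saturated chain carbon bound to two aromatic carbons proves dispensable for this series: a 1.2-fold lower number from compound 2 to compound 3 (0.06 log units; within the scatter) leaves heptyl and 4-bromophenyl indistinguishable, so a chain with no ring serves at this place as well as the ring does. Heptyl also shows the same separation from the 4-hydroxyphenyl group that 4-bromophenyl showed, with a 3.1-fold lower number from compound 1 to compound 3 (0.49 log units; beyond the scatter) as a modest step, so among the three compounds only compound 1 stands apart, and the place accepts two quite different groups without a difference that can be read. Nothing available bears on the reason for this result.

Still open, on these data alone, is how far the chain result extends: a shorter chain such as propyl, a longer chain such as decyl, or a heptyl chain ending in an amine or a carboxylic acid could each hold the number or shift it. As far as these compounds go, the bromo groups of the shared core stay constant across all three compounds, so their contribution, and that of a hydrogen or chloro in their place, remains unknown.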